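Replacing Nitro with Chloro on the Alkynyl Arene

The compounds below may be only part of what the source reports. "The series", "measured", "known", "first", "only" and "open" are said of these compounds alone.

Compound 1 `Cc1nc(C#Cc2cc(C#N)cc([N+](=O)[O-])c2)cs1` gives 2.63 nM in a functional assay on HEK293 cells for antagonist activity at metabotropic glutamate receptor 5 (Rattus norvegicus), read by calcium flux (a higher number here means a weaker inhibitor, a lower number a stronger inhibitor), the highest of the two numbers measured. Compound 2 `Cc1nc(C#Cc2cc(Br)cc([N+](=O)[O-])c2)cs1` gives 0.73 nM in this assay, and the step of a 3.6-fold lower number from compound 1 to compound 2 (0.56 log units; beyond the scatter) is the only one known. Compound 3 `Cc1nc(C#Cc2cc(Cl)cc(C#N)c2)cs1` differs from compound 1 by chloro in place of nitro on an aromatic carbon. The measured step likewise exchanged a non-halogen substituent for a halogen on the same ring and lowered the number, so a modest lowering in this assay is expected here too, a 2.0-fold lower number from compound 1 to compound 3 (0.31 log units; beyond the scatter). Compound 3 is estimated at 1.3 nM, within a range from 0.4 nM to 4.5 nM.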

Compound 3, half-maximal inhibitory concentration: 1.61 nM
Estimate against measurement, compound 3: 1.2-fold (0.09 log units) below; the range from low to high includes it.
By their numbers in this assay, from the lowest: compound 2; then compounds 3 and 1 (each within the scatter of the next).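

In this assay, the nitro group of compound 1 gives way to chloro, which has no hydrogen-bond acceptors, with no change beyond the scatter (a 1.6-fold lower number from compound 1 to compound 3 (0.21 log units; within the scatter)). The nitro group is therefore not needed at this position when the nitrile stays in place, and a single chlorine serves there as well. Nothing measured explains why the two compounds read so alike.

The compounds shown leave open how an amine or a carboxylic acid on this carbon would read. They also leave open whether fluoro or methoxy would match chloro here.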